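Cytotoxicity notes on three measured analogues and one candidate

This account rests on a few compounds, and the source may have more. Where it says the series, first, only, none or still open, it means among the compounds named here.

Compound 2 `Cc1ccc(S(=O)(=O)N[C@@H](CC(=O)NC(C)(C)C)C(=O)NCCNC(=O)c2c(O)cccc2F)cc1` stands at a limit in an ADME assay on Karpas-1106P cells (Homo sapiens) for cytotoxicity; on this read-out higher numbers stand for an effect only at larger amounts of compound and lower numbers for an effect already at smaller amounts: compound 2 gives > 11100 nM, which is a limit of the assay and not a number. Compound 1 `Cc1ccc(S(=O)(=O)N[C@@H](CC(=O)NC(C)(C)C)C(=O)NCCNC(=O)c2cccc(O)c2)cc1` likewise gives a limit, > 11100 nM. Compound 3 `COc1cc(OC)cc(C(=O)NCCNC(=O)[C@H](CC(=O)NC(C)(C)C)NS(=O)(=O)c2ccc(C)cc2)c1` also gives a limit, > 11100 nM. The common picture is the limit of > 11100 nM in this assay, at which 3 of the 3 values shown sit, so the steps a step that the two limits leave unreadable from compound 1 to compound 2, a step that the two limits leave unreadable from compound 1 to compound 3 and a step that the two limits leave unreadable from compound 2 to compound 3 cannot be read. Compound 4 `Cc1ccc(S(=O)(=O)N[C@@H](CC(=O)NC(C)(C)C)C(=O)NCCNC(=O)c2cc(Cl)ccc2Cl)cc1` differs from compound 2 by 2,5-dichlorophenyl in place of 2-fluoro-6-hydroxyphenyl on a carbonyl carbon. Among the compounds with values here, no measured step bears on this change with a readable size; three different aromatic amides on the shared core all reach the limit. Compound 4 is therefore expected to give another limit, estimated as 15000 nM within 7000 nM to 40000 nM. The expected step is a step that the limit leaves unreadable from compound 2 to compound 4.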

Compound 4, half-maximal effective concentration: > 11100 nM
Compound 4 ended at the assay's limit (the forecaster's own chance of this, stated with the estimate: 85%); the middle value does not contradict the limit.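

Compound 4 gives > 11100 nM, which is a limit and not a number. The steps to compound 4 from compound 1, compound 2 and compound 3 therefore cannot be read: the limit of > 11100 nM in this assay, at which 4 of the 4 values shown sit.

The compounds shown leave open how far these four aromatic amides on the shared core differ in cytotoxicity, since none has a readable value.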